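Hydroxymethyl amides against an assay limit in pancreatic cells

The source may report more compounds than this note shows. Statements on the series, on what has been measured and on what is new or still open speak of the compounds shown alone.

Compound 1 `CCn1c(C(=O)NCCC(=O)OC)ccc1C(CC)(CC)c1ccc(OCS(=O)(=O)c2ccccc2)c(C)c1`: > 50000 nM
Compound 2 `CCn1c(C(=O)N[C@@H](CC(=O)OC)C(=O)OC)ccc1C(CC)(CC)c1ccc(OCS(=O)(=O)c2ccccc2)c(C)c1`: > 50000 nM
Compound 3 `CCn1c(C(=O)N[C@H](C)CO)ccc1C(CC)(CC)c1ccc(OCS(=O)(=O)c2ccccc2)c(C)c1`: 10000 nM

In a functional assay on BXPC-3 cells (Homo sapiens) for antiproliferative activity, read by MTT assay, with a stated time of 24 h (on this read-out lower numbers stand for stronger inhibition and higher numbers for weaker inhibition), compound 2 sits at the limit of > 50000 nM in this assay, at which 2 of the 3 values shown sit, which is a limit of the assay and not a number. Compound 1 sits at the same limit. Among the measured compounds shown here, compound 3 is the only measured compound with a number. Compound 4 `CCn1c(C(=O)N[C@@H](CO)C(C)C)ccc1C(CC)(CC)c1ccc(OCS(=O)(=O)c2ccccc2)c(C)c1` differs from compound 2 by 1-(hydroxymethyl)-2-methylpropyl in place of 1,2-bis(methoxycarbonyl)ethyl on an amide-type nitrogen. For the measured compounds named here, the steps that bear on this are an at least 5.0-fold lower number from compound 2 to compound 3 (0.69 log units; beyond the scatter) and an at least 5.0-fold lower number from compound 1 to compound 3 (0.69 log units; beyond the scatter), both of which exchange an ester-bearing chain on the amide nitrogen for a 1-(hydroxymethyl)ethyl group. Since compound 4 also carries a hydroxymethyl-bearing alkyl group there, a step of similar size and direction is expected, an at least 5.0-fold lower number from compound 2 to compound 4 (0.69 log units; beyond the scatter). Compound 4 is therefore estimated at 10000 nM, between 3000 nM and 40000 nM.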

Compound 4, half-maximal inhibitory concentration: 13200 nM
Compound 4: the middle estimate sits 1.3-fold (0.12 log units) below what was measured; the measured number falls inside the stated range.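

In this assay, isopropyl in place of methyl on the saturated chain carbon gives a 1.3-fold higher number from compound 3 to compound 4 (0.12 log units; within the scatter), so the two hydroxymethyl amides cannot be told apart. A second hydroxymethyl-bearing group on the amide-type nitrogen also gives a number, with an at least 3.7-fold lower number from compound 2 to compound 4 (0.57 log units; beyond the scatter) and an at least 3.7-fold lower number from compound 1 to compound 4 (0.57 log units; beyond the scatter). Both of these steps start from a limit of the assay and not a number: the limit of > 50000 nM in this assay, at which 2 of the 4 values shown sit.

Going by these compounds, what stays open is whether the hydroxyl itself matters, since the step sizes rest on limits. On these data alone, a carboxylic acid or an amine on this chain, or a longer chain in place of isopropyl, also remains open.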